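A few compounds are considered here, and "the series" means these few. Any claim that something is new, unique, unknown or untested is made for them only; others in the source may bear on it.

Compound 1, with the structure `CC(C)=CCC1Cc2c(OCc3ccccc3)cc(=O)n(CCCO)c2CC1(C)C`, is the simplest member of this small set. In a functional assay on PANC-1 cells (Homo sapiens) for inhibition, read by MTT assay, with a stated time of 24 h, tested at 10 uM (a higher number here means more inhibition at the concentration tested (going by the name of the read-out), a lower number less inhibition), compound 1 gives -0.3%, which amounts to no measurable effect. Compound 2, `CC(C)=CCOc1cc(=O)n(CCCO)c2c1CC(CC=C(C)C)C(C)(C)C2`, differs from compound 1 in one place: 2-methylprop-1-en-1-yl in place of phenyl on a saturated chain carbon bound to an oxygen on an aromatic ring. In this assay compound 2 gives 20.7%, and the step of a number 21 percentage points higher from compound 1 to compound 2 (beyond the scatter). Compound 3, `CC(C)=CCC/C(C)=C/CC1Cc2c(OCc3ccccc3)cc(=O)n(CCCO)c2CC1(C)C`, keeps the benzyloxy group of compound 1 but carries a longer chain: 3-methylbut-2-en-1-yl in place of hydrogen on a saturated chain carbon bound to a double-bonded chain carbon. In this assay compound 3 gives 46.5%, the highest of the three measured numbers; the step of a number 46.8 percentage points higher from compound 1 to compound 3 (beyond the scatter).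

Compound 4, `CC(C)=CCC/C(C)=C/CC1Cc2c(OCC=C(C)C)cc(=O)n(CCCO)c2CC1(C)C`, has not yet been measured. It stands to compound 3 exactly as compound 2 stands to compound 1: 2-methylprop-1-en-1-yl in place of phenyl on a saturated chain carbon bound to an oxygen on an aromatic ring. The two cores on which this same change is made differ in the way already described for compound 3 against compound 1, namely (3-methylbut-2-en-1-yl in place of hydrogen on a saturated chain carbon bound to a double-bonded chain carbon). The earlier instance of the change, a number 21 percentage points higher from compound 1 to compound 2 (beyond the scatter), is the basis for the expected step of a number 15.5 percentage points higher from compound 3 to compound 4 (beyond the scatter). Among the measured compounds shown here, only one prior example of this change is available, and it was made on a core with a weaker reading, so the expectation carries a wide range. Compound 4 is therefore estimated at 62% in this assay, with a likely span from 40% to 84%.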

Compound 4, a percentage reported as inhibition, at one concentration (the size of the read-out at that concentration, not a potency): 30.3%
Estimate against measurement, compound 4: 31.7 percentage points above; measured number outside the range, below it.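

The change from benzyloxy to (3-methylbut-2-en-1-yl)oxy does not carry over from one core to the other in this assay: with the longer chain already in place the step is a number 16.2 percentage points lower from compound 3 to compound 4 (beyond the scatter), and the direction is the opposite of the earlier one: the same change on two cores in this assay, a number 21 percentage points higher (beyond the scatter) from compound 1 to compound 2 and a number 16.2 percentage points lower (beyond the scatter) from compound 3 to compound 4, 37.2 percentage points apart, beyond the scatter of two such steps The longer chain, read the other way round, also depends on its partner, since with (3-methylbut-2-en-1-yl)oxy in place of benzyloxy the step is only a number 9.6 percentage points higher from compound 2 to compound 4 (within the scatter), far smaller than the earlier one: the same change on two cores in this assay, a number 46.8 percentage points higher (beyond the scatter) from compound 1 to compound 3 and a number 9.6 percentage points higher (within the scatter) from compound 2 to compound 4, 37.2 percentage points apart, beyond the scatter of two such steps This shows that, for these four compounds, the effects of the two changes do not simply add up, so a step seen on one core is a poor guide to the same step on the other, but it does not show why, and with a single pair per core and one tested concentration it sets no rule for the wider series.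

As far as these compounds go, it remains open how the two chains would behave with another group in place of phenyl on that saturated chain carbon, such as a cyclohexyl ring or a chain ending in an amine. From the compounds shown here alone, it also remains open whether the same dependence would appear with a still longer chain in place of the 3-methylbut-2-en-1-yl group.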